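The source may hold more compounds than are shown below. What is called first, only, known or untested is meant among the compounds shown, and "the series" means these compounds.

Measured so far in a functional assay on MGC-803 cells (Homo sapiens) for inhibition, read by MTT assay, with a stated time of 72 h; a higher number here means a weaker inhibitor, a lower number a stronger inhibitor:
compound 1 `FC(F)(F)c1ccc(CSc2nc(N3CCNCC3)cc(C(F)(F)F)n2)cc1`: 5870 nM
compound 2 `CN1CCN(c2cc(C(F)(F)F)nc(SCc3ccc(C(F)(F)F)cc3)n2)CC1`: 15800 nM
compound 3 `CCN1CCN(c2cc(C(F)(F)F)nc(SCc3ccc(C(F)(F)F)cc3)n2)CC1`: 25600 nM

Compound 1 stands lowest of the three numbers and is the strongest inhibitor in this set. Compound 2 is its nearest neighbour (a 2.7-fold higher number from compound 1 to compound 2 (0.43 log units; beyond the scatter)), and compound 3 is furthest away (a 4.4-fold higher number from compound 1 to compound 3 (0.64 log units; beyond the scatter)). Between compounds 2 and 3 the step is a 1.6-fold higher number from compound 2 to compound 3 (0.21 log units; within the scatter).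

Compound 4 `FC(F)(F)c1ccc(CSc2nc(SC3=NCCS3)cc(C(F)(F)F)n2)cc1` has not been measured in this assay. It differs from compound 1 in one place: a group of 6 heavy atoms (3 carbon, 1 nitrogen, 2 sulfur; one five-membered non-aromatic ring with 2 hetero atoms) in place of a group of 6 heavy atoms (4 carbon, 2 nitrogen; one six-membered non-aromatic ring with 2 hetero atoms), on an aromatic carbon. Here the piperazin-1-yl group is removed altogether rather than only altered at its amine nitrogen. Within the data shown here, the measured steps bear on this only at a distance, yet they point one way: because a 2.7-fold higher number from compound 1 to compound 2 (0.43 log units; beyond the scatter) and a 4.4-fold higher number from compound 1 to compound 3 (0.64 log units; beyond the scatter) both raised the number when that amine nitrogen was changed, a higher number is expected for compound 4 as well, with wide uncertainty since no measured compound carries the entering group. Compound 4 is estimated at 15000 nM, within a range of 4000 nM to 60000 nM. The expected step is a 2.6-fold higher number from compound 1 to compound 4 (0.41 log units; beyond the scatter).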

Compound 4, half-maximal inhibitory concentration: 24500 nM
Compound 4: middle estimate off by 1.6-fold (0.21 log units), on the low side; measured number inside the range.
By their numbers in this assay, from the lowest: compound 1; then compounds 2, 4 and 3 (each within the scatter of the next).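

Swapping the whole piperazin-1-yl group for a five-membered non-aromatic ring with sulfur atoms raises the number, a 4.2-fold higher number from compound 1 to compound 4 (0.62 log units; beyond the scatter), so compound 1 remains the strongest inhibitor of the four, and the rise seen on changing its amine nitrogen now extends to a change that removes the six-membered ring altogether. The new group cannot be told apart from the substituted piperazines, with a 1.6-fold higher number from compound 2 to compound 4 (0.19 log units; within the scatter) and a 1.0-fold lower number from compound 3 to compound 4 (0.02 log units; within the scatter), so two quite different groups on this aromatic carbon give numbers within the scatter of each other. Nothing available here explains why these changes raise the number.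

From the compounds shown here alone, whether a morpholine ring or a simple open-chain amine on this carbon would match compound 1 remains open. Also open, going by these compounds, is how a piperazine carrying an acetyl group on that nitrogen would compare.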